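A few compounds are considered here, and "the series" means these few. Any claim that something is new, unique, unknown or untested is made for them only; others in the source may bear on it.

Compound 1 `O=C(O)c1ccccc1-c1ccc(CCc2ncc(CC3CCC3)[nH]2)cc1` gives 7.1 nM in an in vitro functional assay on cells for agonist activity at Bombesin receptor subtype-3 (Mus musculus), read by luminescence and calcium flux (on this read-out higher numbers stand for an effect only at larger amounts of compound and lower numbers for an effect already at smaller amounts), and compound 2 `O=C(O)c1ccccc1-c1ccc(CCc2ncc(Cc3ccccc3F)[nH]2)cc1` gives 9.5 nM. Of these two numbers compound 2 has the higher one, but the step of a 1.3-fold higher number from compound 1 to compound 2 (0.13 log units; within the scatter) lies within the scatter. Compound 3 `O=C(O)c1ccccc1-c1ccc(CCc2ncc(Cc3cccc(Cl)c3)[nH]2)cc1` differs from compound 2 by 3-chlorophenyl in place of 2-fluorophenyl on a saturated chain carbon bound to an aromatic carbon. Among the compounds with values here, the only step that bears on this change is the one from compound 1 to compound 2, which swapped groups at the same place without a change beyond the scatter. Compound 3 is therefore expected to give 10 nM, within 4 nM to 25 nM. The expected step is a 1.1-fold higher number from compound 2 to compound 3 (0.02 log units; within the scatter), none beyond the scatter.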

Compound 3, half-maximal effective concentration: 31 nM
For compound 3 the middle estimate is 3.1-fold (0.49 log units) below the measured one, outside the stated range (above it).
By their numbers in this assay, from the lowest: compounds 1 and 2 (each within the scatter of the next); then compound 3.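

At this place, on a saturated chain carbon bound to an aromatic carbon, the group is not freely interchangeable: in this assay 3-chlorophenyl brings a 3.3-fold higher number from compound 2 to compound 3 (0.51 log units; beyond the scatter) and also a 4.4-fold higher number from compound 1 to compound 3 (0.64 log units; beyond the scatter) even though cyclobutyl and 2-fluorophenyl could not be told apart. Nothing available here accounts for this shift. Because 2-fluorophenyl and 3-chlorophenyl differ in both the halogen and its place on the ring, the compounds shown do not separate these two changes. On these data alone, whether 2-chlorophenyl, 3-fluorophenyl or unsubstituted phenyl would fall with compound 2 or with compound 3 remains open.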